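The source may hold more compounds than are shown below. What is called first, only, known or untested is meant among the compounds shown, and "the series" means these compounds.

Measured so far in a functional assay on U-87MG ATCC cells (Homo sapiens) for antiproliferative activity, read by MTT assay, with a stated time of 48 h; on this read-out lower numbers stand for stronger inhibition and higher numbers for weaker inhibition:
compound 1 `COc1cc(N/C=C\C(=O)c2cn(-c3ccccc3)nc2-c2ccc(Cl)cc2)cc(OC)c1OC`: 17800 nM
compound 2 `COc1ccc(-c2nn(-c3ccccc3)cc2C(=O)/C=C\Nc2ccc(F)cc2)cc1`: 8910 nM
compound 3 `COc1ccc(-c2nn(-c3ccccc3)cc2C(=O)/C=C\Nc2ccc(Cl)cc2)cc1`: 8860 nM

Compound 3 sits at the lowest of the three numbers, but its gaps to compound 2 and to compound 1 both lie within the scatter, so no ordering among them is claimed. The step to compound 4 `COc1ccc(-c2nn(-c3ccccc3)cc2C(=O)/C=C\Nc2cc(OC)c(OC)c(OC)c2)cc1` changes (3,4,5-trimethoxyphenyl in place of 4-chlorophenyl on an amine nitrogen). Within the data shown here, the only measured step, a 1.0-fold lower number from compound 2 to compound 3 (0.00 log units; within the scatter), exchanges one halogen for another on an aromatic carbon and says nothing about the entering group. Compound 1 already carries a 3,4,5-trimethoxyphenyl on its amine nitrogen, though it differs elsewhere as well; in this assay compound 1 gives 17800 nM, within the scatter of compound 3. No step beyond the scatter is therefore expected for a 1.4-fold higher number from compound 3 to compound 4 (0.13 log units; within the scatter). Compound 4 is estimated at 12000 nM, with a range from 5000 nM to 30000 nM.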

Compound 4, half-maximal inhibitory concentration: > 50000 nM
Compound 4 gave a limit, no number; the forecaster's own chance of this, stated with the estimate: 5%; at least 4.1-fold (0.61 log units) between middle value and limit.
By their numbers in this assay, from the lowest: compounds 3, 2 and 1 (each within the scatter of the next). At a limit, above all of these: compound 4.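

On an amine nitrogen, 3,4,5-trimethoxyphenyl in place of 4-chlorophenyl gives an at least 5.6-fold higher number from compound 3 to compound 4 (0.75 log units; beyond the scatter), and in place of 4-fluorophenyl it gives an at least 5.6-fold higher number from compound 2 to compound 4 (0.74 log units; beyond the scatter), so this position responds to the group it carries, which the halogen exchange did not show. The 3,4,5-trimethoxyphenyl group does not set the outcome alone: with it kept, methoxy in place of chloro on an aromatic carbon gives an at least 2.8-fold higher number from compound 1 to compound 4 (0.44 log units; beyond the scatter). In this assay compound 4 stands at a limit, not a number: the limit of > 50000 nM in this assay, at which 1 of the 4 values shown sits.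

The compounds shown leave open whether a single methoxy or an amine on the phenyl group at this nitrogen would keep the number near those of compound 2 and compound 3. On these data alone, how far the steps to compound 4 truly reach also stays open.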